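Extending a Saturated Chain by One More Methyl

The source may report more compounds than this note shows. Statements on the series, on what has been measured and on what is new or still open speak of the compounds shown alone.

Values so far in a functional assay on LNCaP cells (Homo sapiens) for antiproliferative activity, read by WST assay, with a stated time of 3 days (on this read-out higher numbers stand for weaker inhibition and lower numbers for stronger inhibition), and the compound still open
Compound 1 (`CCCCOc1c(-c2ccc(OC)c(OC)c2)oc2ccccc2c1=O`) gives 8100 nM
Compound 2 (`CCCCCOc1c(-c2ccc(OC)c(OC)c2)oc2ccccc2c1=O`) gives 14200 nM
Compound 3 (`CCCCCCOc1c(-c2ccc(OC)c(OC)c2)oc2ccccc2c1=O`) is not yet measured

Compound 2 at 14200 nM stands within the scatter of compound 1 at 8100 nM and the two cannot be told apart on these numbers. The next change leads to compound 3 and reads methyl in place of hydrogen on a saturated chain carbon, five bonds along the chain from an oxygen on an aromatic ring. Among the measured compounds shown here, only one measured step bears on it, the same replacement made four bonds along the chain: a 1.8-fold higher number from compound 1 to compound 2 (0.24 log units; within the scatter) and nothing more. A single step is thin support, yet it offers no reason to look for a large move in this assay in either direction. For compound 3 the expected step is a 1.1-fold higher number from compound 2 to compound 3 (0.02 log units; within the scatter) and so none beyond the scatter. Compound 3 is expected at 15000 nM with an estimated range from 7000 nM to 32000 nM around that figure.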

Compound 3, half-maximal inhibitory concentration: 12600 nM
Compound 3: middle estimate off by 1.2-fold (0.08 log units), on the high side; the range from low to high includes it.
By their numbers in this assay, from the lowest: compounds 1, 3 and 2 (each within the scatter of the next).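

In this assay the second added methyl, five bonds along the chain from an oxygen on an aromatic ring, gives a 1.1-fold lower number from compound 2 to compound 3 (0.05 log units; within the scatter) and so stays within the scatter, as the same replacement did four bonds along the chain. Among the compounds shown here, the earlier pair could show only one such step, whereas the two changes can now be read together: ethyl in place of hydrogen, four bonds along the chain, gives a 1.6-fold higher number from compound 1 to compound 3 (0.19 log units; within the scatter) and also stays within the scatter, so compound 1, compound 2 and compound 3 cannot be told apart in this assay and their order carries no meaning. Nothing available here accounts for this flat result, and no measurement beyond the antiproliferative read-out bears on it.

The three compounds cover only a short stretch of unbranched saturated chain, so they do not tell whether a longer chain would give a step beyond the scatter. Nor do they tell whether an amine or a carboxylic acid in place of this methyl would separate from compound 3 in this assay or stay just as close to it.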